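Trimming ethoxycarbonyl to methoxycarbonyl

The compounds below may be only part of what the source reports. "The series", "measured", "known", "first", "only" and "open" are said of these compounds alone.

Measured in an ADME assay on the whole organism (Rattus norvegicus, strain Sprague-Dawley) for pharmacokinetics, read by LC-MS, with a stated time of 48 h, at a dose of 10 mg/kg by the oral route; a higher number here means more compound in the circulation at the dose given, a lower number less compound in the circulation:
- compound 1 `CC#CCn1c(N2CCC[C@@H](N)C2)nc2c1c(=O)n(Cc1ccc(Cl)cc1C(=O)O)c(=O)n2C`: 4820 nM
- compound 2 `CC#CCn1c(N2CCC[C@@H](N)C2)nc2c1c(=O)n(Cc1ccc(Cl)cc1C(=O)OCC)c(=O)n2C`: 990 nM

Of these two, compound 2 holds the lower number, 990 nM. Compound 3 `CC#CCn1c(N2CCC[C@@H](N)C2)nc2c1c(=O)n(Cc1ccc(Cl)cc1C(=O)OC)c(=O)n2C` turns ethoxycarbonyl into methoxycarbonyl: hydrogen in place of methyl on a saturated chain carbon bound to an oxygen next to a carbonyl group. Among the measured compounds shown here, the one measured step that bears on this is a 4.9-fold lower number from compound 1 to compound 2 (0.69 log units; beyond the scatter), where a whole ethyl replaced hydrogen on such an oxygen. Removing only part of that ethyl should therefore move this assay a little back towards compound 1, by far less than that step. The expected step is a 1.3-fold higher number from compound 2 to compound 3 (0.12 log units; within the scatter). For compound 3 the estimate is 1300 nM, with an expected range of 550 nM to 3000 nM.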

Compound 3, maximal plasma concentration: 2370 nM
Compound 3: the middle estimate sits 1.8-fold (0.26 log units) below what was measured; the measured number falls inside the stated range.
By their numbers in this assay, from the lowest: compound 2; then compound 3; then compound 1.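

The number in this assay responds to a single methyl on this ester: ethoxy to methoxy gives a 2.4-fold higher number from compound 2 to compound 3 (0.38 log units; beyond the scatter) and so the length of the chain counts here, not merely the presence of an ester. The methyl ester still stays apart from the free acid, with a 2.0-fold lower number from compound 1 to compound 3 (0.31 log units; beyond the scatter) and the three compounds rise in the order ethyl ester, methyl ester, acid. No measurement here explains these shifts. Going by these compounds, whether a longer chain such as propyl would lower the number further remains open, as does an amide in place of the ester.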